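Swapping a Hydroxy for a Pyrazole on the Amide Nitrogen

A few compounds are considered here, and "the series" means these few. Any claim that something is new, unique, unknown or untested is made for them only; others in the source may bear on it.

Of the compounds shown here, three sharing one core have been measured in an assay on HEK293 cells for agonist activity at transient receptor potential cation channel subfamily M member 8 (Homo sapiens), read by fluorescence and calcium flux, with a stated time of 15 min; on this read-out higher numbers stand for an effect only at larger amounts of compound and lower numbers for an effect already at smaller amounts. Compound 1 `Cc1ccc(OCC(=O)N(Cc2cccs2)c2ccnn2C)cc1` gives 422 nM, compound 2 `Cc1ccc(OCC(=O)N(Cc2cccs2)C(C)C)cc1` gives 70 nM, and compound 3 `Cc1ccc(OCC(=O)N(O)Cc2cccs2)cc1` gives 8000 nM. Compound 3 stands at the highest number of the three: the step of a 19-fold higher number from compound 1 to compound 3 (1.28 log units; beyond the scatter) and the step of a 110-fold higher number from compound 2 to compound 3 (2.06 log units; beyond the scatter) both mark it as the compound that needs the largest amount. Compound 4 `Cc1ccc(OCC(=O)N(Cc2cccs2)c2cn[nH]c2)cc1` changes it in one place: 1H-pyrazol-4-yl in place of hydroxy on an amide-type nitrogen. Both measured steps bear on this change, since each replaced a carbon-based group on the amide nitrogen with a hydroxy and raised the number sharply; the reverse direction should therefore lower it. The closest guide is compound 1, whose group on that nitrogen is also a pyrazole, though a different isomer without the methyl. On that basis a large drop is expected, a 16-fold lower number from compound 3 to compound 4 (1.20 log units; beyond the scatter), in this assay. Compound 4 is estimated at 500 nM, with a range from 150 nM to 2500 nM.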

Compound 4, half-maximal effective concentration: 1.4 nM
Compound 4: the middle estimate sits 360-fold (2.55 log units) above what was measured; measured number outside the range, below it.
By their numbers in this assay, from the lowest: compound 4; then compound 2; then compound 1; then compound 3.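

The earlier compounds shown here showed only that hydroxy on this amide-type nitrogen does worse than the two carbon-linked groups, but a ring can do far better than either of them: 1H-pyrazol-4-yl gives a 5700-fold lower number from compound 3 to compound 4 (3.76 log units; beyond the scatter) and also improves on isopropyl, with a 50-fold lower number from compound 2 to compound 4 (1.70 log units; beyond the scatter) in the same direction. The exact form of the pyrazole matters greatly, since a 300-fold lower number from compound 1 to compound 4 (2.48 log units; beyond the scatter) separates two pyrazole groups on the same nitrogen, so the presence of such a ring is not enough on its own. No evidence on hand explains this result.

The compounds shown leave open whether the methyl or the point of attachment accounts for that gap, a question that 1-methyl-1H-pyrazol-4-yl would help settle. On these data alone, how other rings, such as 1H-imidazol-4-yl or phenyl, would behave on this nitrogen also remains open.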